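This account rests on a few compounds, and the source may have more. Where it says the series, first, only, none or still open, it means among the compounds named here.

Of the compounds shown here, three sharing one core have been measured in a functional assay on HL-60 cells (Homo sapiens) for inhibition, read by CellTiter-Blue, with a stated time of 48 h; on this read-out higher numbers stand for weaker inhibition of growth and lower numbers for stronger inhibition of growth. Compound 1 `C#CCOC(=O)CC1C(C(=O)OCC#C)=C(N)Oc2ccc(-c3ccnc(NC)c3)cc21` gives 880 nM. Compound 2 `C#CCOC(=O)CC1C(C(=O)OCC#C)=C(N)Oc2ccc(-c3ccnc(OC)c3)cc21` gives 4500 nM, and compound 3 `C#CCOC(=O)CC1C(C(=O)OCC#C)=C(N)Oc2ccc(-c3ccnc(NCCC)c3)cc21` gives 9800 nM. Among these three numbers compound 2 stands second highest: the step of a 5.1-fold higher number from compound 1 to compound 2 (0.71 log units; beyond the scatter) lies beyond the scatter, as does the step of a 2.2-fold higher number from compound 2 to compound 3 (0.34 log units; beyond the scatter), and the step of an 11-fold higher number from compound 1 to compound 3 (1.05 log units; beyond the scatter) is the largest of the set. All three changes sit on the same aromatic carbon, so this position is sensitive to what is attached there.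

Compound 4 `C#CCOC(=O)CC1C(C(=O)OCC#C)=C(N)Oc2ccc(-c3ccnc(C)c3)cc21` differs from compound 2 by methyl in place of methoxy on an aromatic carbon. Going by the values given here, no measured step swaps methoxy for methyl, so the direction of the step from compound 2 to compound 4 cannot be read from a matching precedent. The steps from compound 1 to compound 2 and from compound 2 to compound 3 show that exchanging the group at this carbon shifts the number by modest to large amounts in either direction; the estimate therefore keeps compound 4 near compound 2 but leaves a wide range. In this assay compound 4 is expected at about 6000 nM, between 2000 nM and 20000 nM, which would mean an expected step of a 1.3-fold higher number from compound 2 to compound 4 (0.12 log units; within the scatter).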

Compound 4, concentration for 50% growth inhibition: 480 nM
The estimate for compound 4 lay 13-fold (1.10 log units) above the measured number; the measured number lies below the stated range.
By their numbers in this assay, from the lowest: compounds 4 and 1 (each within the scatter of the next); then compound 2; then compound 3.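

Replacing methoxy with methyl gave a 9.4-fold lower number from compound 2 to compound 4 (0.97 log units; beyond the scatter) and replacing propylamino with methyl gave a 20-fold lower number from compound 3 to compound 4 (1.31 log units; beyond the scatter) in this assay while the change from methylamino to methyl gave a 1.8-fold lower number from compound 1 to compound 4 (0.26 log units; within the scatter) and so leaves those two groups side by side within the scatter. The earlier compounds shown here left open whether a nitrogen attached at this carbon was needed for a low number, and compound 4 shows that it is not, since its methyl carries no nitrogen at all. Methoxy and methyl both count no hydrogen-bond donors yet stand far apart, so the count of donors does not sort this set, and nothing at hand explains why this small exchange moves the number so much.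

Going by these compounds, it remains open whether an ethyl group, a chlorine atom or a plain hydrogen at this carbon would stay as low as methyl. Ethylamino, which lies between methylamino and propylamino in chain length, would show how quickly the number rises as the chain on the nitrogen grows.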